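The source may hold more compounds than are shown below. What is called first, only, known or untested is meant among the compounds shown, and "the series" means these compounds.

Measured compounds in a functional assay on thoracic aorta (Rattus norvegicus, strain Wistar) for inhibition, in the presence of a further agent that is not named here; on this read-out lower numbers stand for an effect already at smaller amounts and higher numbers for an effect only at larger amounts of compound:
compound 1 `O=C(O)c1ccc(OCCCO[N+](=O)[O-])cc1`, compound 1 gives 66000 nM
compound 2 `O=C(O)CCCCCO[N+](=O)[O-]`, compound 2 gives > 100000 nM

Compound 2 stands at the edge of what this assay resolves: its value is a limit of the assay and not a number, so the effect of compound 2 was not reached within the tested amounts. The record notes (the limit of > 100000 nM in this assay, at which 1 of the 2 values shown sits), and compound 2 is the one that sits there. Compound 1, with its aromatic ring, is the only one of the two with a measured number.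

The step to compound 3 `O=[N+]([O-])OCCCCCCO` is hydroxymethyl in place of carboxy on a saturated chain carbon, five bonds along the chain from an oxygen on an unsaturated carbon. Among the measured compounds shown here, no measured pair follows this change, so nothing here shows how large a step it brings in this assay. The closest point of reference remains compound 2 itself, which gave only a limit; an unmeasured chain compound of the same length, with a hydroxymethyl end instead of a carboxy end, is expected to stay near that region, with any step from compound 2 to compound 3 estimated as an at least 1.2-fold lower number from compound 2 to compound 3 (0.09 log units; that floor lies within the scatter). Compound 3 is therefore expected to give about 80000 nM, within a range from 20000 nM to 300000 nM, and a renewed limit rather than a number is a real possibility.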

Compound 3, half-maximal effective concentration: > 100000 nM
Compound 3: only a limit was reported (the forecaster's own chance of this, stated with the estimate: 50%); at least 1.2-fold (0.09 log units) between middle value and limit.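

Compound 3 gives > 100000 nM in this assay and this is a limit of the assay, not a number. Compound 2 also gave only a limit, so no step can be read between compound 2 and compound 3: the limit of > 100000 nM in this assay, at which 2 of the 3 values shown sit. The compounds shown leave open whether hydroxymethyl in place of carboxy on this chain changes the effect at all.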